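This account rests on a few compounds, and the source may have more. Where it says the series, first, only, none or still open, it means among the compounds named here.

The measured compounds:
compound 1, `O=C(/C=C/c1cccc([N+](=O)[O-])c1)c1ccc[nH]1`, 23000 nM
compound 2, `O=C(/C=C/c1ccc(Cl)cc1)c1ccc[nH]1`, 18000 nM
compound 3, `O=C(/C=C/c1ccc(Cl)cc1)c1ccco1`, 29000 nM

All three were tested in a functional assay on PC-3 cells (Homo sapiens) for inhibition, read by MTT assay, with a stated time of 48 h; a higher number here means a weaker inhibitor, a lower number a stronger inhibitor. Compound 2 and compound 3 share a core and differ in one place: furan-2-yl in place of 1H-pyrrol-2-yl on a carbonyl carbon. That change gave a 1.6-fold higher number from compound 2 to compound 3 (0.21 log units; within the scatter). Compound 1 carries a core that is not the core of compound 2, and the difference between the two cores is not broken down here; compound 1 gives 23000 nM, and compound 2 gives 18000 nM, and these two numbers lie within the scatter of each other. Compound 4, `O=C(/C=C/c1cccc([N+](=O)[O-])c1)c1ccco1`, has not yet been measured. It is derived from compound 1 by the same change that was made earlier: furan-2-yl in place of 1H-pyrrol-2-yl on a carbonyl carbon. The step from compound 1 to compound 4 in this assay is expected to be of a similar small size, a 1.6-fold higher number from compound 1 to compound 4 (0.21 log units; within the scatter), because the same change on the other core gave a 1.6-fold higher number from compound 2 to compound 3 (0.21 log units; within the scatter). The estimate for compound 4 is therefore 37000 nM, with a range from 15000 nM to 90000 nM.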

Compound 4, half-maximal inhibitory concentration: 14000 nM
Compound 4: middle estimate off by 2.6-fold (0.42 log units), on the high side, outside the stated range (below it).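

In this assay, putting furan-2-yl in place of 1H-pyrrol-2-yl on a carbonyl carbon gave a 1.6-fold lower number from compound 1 to compound 4 (0.22 log units; within the scatter). Set beside the same change on the core of compound 2, this step shows no difference between the two cores that can be told from the scatter: the same change on two cores in this assay, a 1.6-fold higher number (0.21 log units; within the scatter) from compound 2 to compound 3 and a 1.6-fold lower number (0.22 log units; within the scatter) from compound 1 to compound 4, 2.6-fold (0.42 log units) apart, within the scatter of two such steps. On these two pairs the change therefore carries from one core to the other as a step too small to read, but neither step gives it a direction, and two pairs do not show that it would stay this small on other cores in the series.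

The compounds shown leave open whether the change stays as small when an amine, a carboxylic acid or a longer chain stands in place of the nitro or chloro group on the shared core. They also leave open whether it would stay as small in any other cell line or read-out.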